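The source may hold more compounds than are shown below. What is called first, only, known or untested is meant among the compounds shown, and "the series" means these compounds.

Series notes. Compound 3 `COc1cc(NC(C)CCCNC(=O)/C=C/c2ccccc2F)c2ncccc2c1` carries a 2-(2-fluorophenyl)ethenyl group on the amide carbonyl of the shared core. For the measured compounds named here, in an ADME assay on L6 cells (Rattus norvegicus) for cytotoxicity, read by resazurin assay, with a stated time of 70 h (on this read-out lower numbers stand for stronger inhibition and higher numbers for weaker inhibition), compound 3 gives 1.5 ug/mL, the only number recorded among the three measured compounds. Compound 1 `COc1ccc(/C=C/C(=O)NCCCC(C)Nc2cc(OC)cc3cccnc23)cc1` reaches only a limit of this assay, > 100 ug/mL. Compound 2 `COc1cc(NC(C)CCCNC(=O)/C=C/c2ccc(OC)c(OC)c2)c2ncccc2c1` likewise reaches only a limit, > 100 ug/mL. The step that the two limits leave unreadable from compound 1 to compound 2 therefore cannot be read. The steps of an at least 66-fold lower number from compound 1 to compound 3 (1.82 log units; beyond the scatter) and an at least 66-fold lower number from compound 2 to compound 3 (1.82 log units; beyond the scatter) are both large, and both run toward the 2-fluorophenyl group; the limit of > 100 ug/mL in this assay, at which 2 of the 3 values shown sit, marks where the other two values sit.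

Compound 4 `COc1cc(NC(C)CCCNC(=O)Nc2cccc(F)c2)c2ncccc2c1` is not yet measured. The change: (3-fluorophenyl)amino in place of 2-(2-fluorophenyl)ethenyl on a carbonyl carbon. Going by the values given here, none of the measured steps touches this place. Among the compounds with values here, all three alter the aryl group on the double-bonded chain carbon, and compound 4 removes that chain altogether, so no measured step bears directly on it. Within the data shown here, the one compound with a number rather than a limit, compound 3, carries the 2-(2-fluorophenyl)ethenyl group; with it gone, the expected step is a 20-fold higher number from compound 3 to compound 4 (1.30 log units; beyond the scatter), a move back toward the limit. For compound 4 the estimate in this assay is 30 ug/mL, with a range from 3 ug/mL to 100 ug/mL, and a fair chance that only a limit is reported.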

Compound 4, half-maximal inhibitory concentration: 9.18 ug/mL
The estimate for compound 4 lay 3.3-fold (0.51 log units) above the measured number; low and high end bracket the measured number.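

In this assay, (3-fluorophenyl)amino in place of 2-(2-fluorophenyl)ethenyl on the carbonyl carbon gives a 6.1-fold higher number from compound 3 to compound 4 (0.79 log units; beyond the scatter), a modest step, so a number at this place does not depend on the double bond outside aromatic rings. Set against the 2-(4-methoxyphenyl)ethenyl group, the same (3-fluorophenyl)amino group gives an at least 10-fold lower number from compound 1 to compound 4 (1.03 log units; beyond the scatter), a large step, so this place now has two fluorinated groups that give a number rather than a limit. Among the four compounds, the two with a fluorophenyl group, compound 3 and compound 4, give numbers, while the two with methoxy groups on that aryl ring, compound 1 and compound 2, stay at a limit, and no compound shown goes against this: the limit of > 100 ug/mL in this assay, at which 2 of the 4 values shown sit.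

Open, as far as these compounds go, is how the step from compound 3 to compound 4 divides between the change of link and the change in the fluorine's place on the ring, as both differ together, while the step between compound 1 and compound 2 cannot be read. Also open, from the compounds shown here alone, is whether an amine or a carboxylic acid on that aryl ring, or a longer chain in the shared core, would keep a number in this assay or return to a limit.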